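From chloro to methyl in a growth inhibition series

A few compounds are considered here, and "the series" means these few. Any claim that something is new, unique, unknown or untested is made for them only; others in the source may bear on it.

In a functional assay on NCI-H460 cells (Homo sapiens) for inhibition (a lower number here means a stronger inhibitor of growth, a higher number a weaker inhibitor of growth), compound 2 `Nc1ccc(-c2nc3ccc(F)cc3s2)cc1Cl` gives 100 nM and holds the lower of the two actual numbers. Compound 3 `Cc1cc(-c2nc3cccc(F)c3s2)ccc1N` gives 4200 nM as the other number, well beyond the scatter from it. Compound 1 `Nc1ccc(-c2nc3ccc(F)cc3s2)cc1I` has only the limit > 100000 nM as its result. Chloro in place of iodo gave an at least 1000-fold lower number from compound 1 to compound 2 (3.00 log units; beyond the scatter) as a large step, the only measured step bearing on this change. Compound 4 `Cc1cc(-c2nc3ccc(F)cc3s2)ccc1N` has methyl in place of chloro on an aromatic carbon, ortho to an amino group, with methyl in place of chloro on an aromatic carbon as the counted difference. Compound 3 also carries methyl, and its 4200 nM points upward. A moderately higher number is therefore expected in this assay, with a 3.0-fold higher number from compound 2 to compound 4 (0.48 log units; beyond the scatter) as the estimated step. The estimate for compound 4 is 300 nM (expected range 30 nM to 5000 nM).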

Compound 4, concentration for 50% growth inhibition: 100 nM
Estimate against measurement, compound 4: 3.0-fold (0.48 log units) above; the measured number falls inside the stated range.
By their numbers in this assay, from the lowest: compounds 2 and 4 (each within the scatter of the next); then compound 3. At a limit, above all of these: compound 1.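

In this assay, methyl in place of chloro at this position, ortho to an amino group, gives no change at the digits printed from compound 2 to compound 4 (within the scatter), so this assay does not separate the two groups here. Methyl in place of iodo gives an at least 1000-fold lower number from compound 1 to compound 4 (3.00 log units; beyond the scatter), which leaves iodo as the one group of the three that stands apart at this position. Compound 1 is known only by a limit, so that step is a bound and not a measured size: the limit of > 100000 nM in this assay, at which 1 of the 4 values shown sits. As far as these compounds go, whether a bromo, an ethyl or a methoxy group at this position would match chloro and methyl, or fall towards iodo, stays open.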